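A few compounds are considered here, and "the series" means these few. Any claim that something is new, unique, unknown or untested is made for them only; others in the source may bear on it.

Compound 3 `COc1ccc(F)cc1CNCCCNc1ccnc2cc(Cc3ccc(C#N)cc3)ccc12` stands second highest of the three compounds measured in an ADME assay on HepG2 cells (Homo sapiens) for cytotoxicity, read by luminescence, CellTiter-Glo and ATP content, with a stated time of 72 h (on this read-out higher numbers stand for an effect only at larger amounts of compound and lower numbers for an effect already at smaller amounts), where compound 3 gives 6050 nM. Compound 1 `COc1cccc(Oc2ccc3c(NCCCNCc4cc(F)ccc4OC)ccnc3c2)c1` gives 7100 nM, and compound 2 `COc1ccc(F)cc1CNCCCNc1ccnc2cc(CC(C)C)ccc12` gives 2900 nM. Compound 4 `COc1ccc(F)cc1CNCCCNc1ccnc2cc(-c3ccc(F)cc3)ccc12` differs from compound 3 in one place: 4-fluorophenyl in place of 4-cyanobenzyl on an aromatic carbon. Two measured steps end at compound 3: a 1.2-fold lower number from compound 1 to compound 3 (0.07 log units; within the scatter) and a 2.1-fold higher number from compound 2 to compound 3 (0.32 log units; beyond the scatter). Neither replaces one aromatic group with another aromatic group, so they bear on this change only loosely; together they show that exchanges at this aromatic carbon have moved the number by at most a modest amount. A step of no more than modest size, in either direction, is therefore expected in this assay, a 1.2-fold lower number from compound 3 to compound 4 (0.08 log units; within the scatter). Compound 4 is estimated at 5000 nM, with a range from 2500 nM to 10000 nM.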

Compound 4, half-maximal effective concentration: 770 nM
Compound 4: the middle estimate sits 6.5-fold (0.81 log units) above what was measured; measured number outside the range, below it.
By their numbers in this assay, from the lowest: compound 4; then compound 2; then compounds 3 and 1 (each within the scatter of the next).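

Set on this aromatic carbon, 4-fluorophenyl brings a 7.9-fold lower number from compound 3 to compound 4 (0.90 log units; beyond the scatter) and a 3.8-fold lower number from compound 2 to compound 4 (0.58 log units; beyond the scatter) and a 9.2-fold lower number from compound 1 to compound 4 (0.96 log units; beyond the scatter) in this assay and gives the lowest number of the four. These steps are larger than any earlier step at this place, so the position can move the number further than compound 1, compound 2 and compound 3 had shown. No measurement at hand accounts for this shift. On these data alone, whether it comes from the ring sitting directly on the core or from its fluorine stays open, as does what an amine or a carboxylic acid on this carbon would give.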